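Swapping a Sulfonamide Phenyl for a Hydroxymethyl Phenyl

The source may hold more compounds than are shown below. What is called first, only, known or untested is meant among the compounds shown, and "the series" means these compounds.

Of the compounds shown here, three sharing one core have been tested in a functional assay on blood for antagonist activity at thromboxane A2 receptor (Homo sapiens); a lower number here means tighter binding, a higher number weaker binding. Compound 1 `CS(=O)(=O)Nc1cccc(-c2ccc(COC3CC[C@H](N4CCCCCC4)[C@H]3OC/C=C\CCC(=O)O)cc2)c1` gives 12.6 nM. That is the second highest of the three numbers: compound 2 `O=C(O)CC/C=C\CO[C@H]1[C@@H](OCc2ccc(-c3ccc(CO)cc3)cc2)CC[C@@H]1N1CCCCCC1` gives 3.98 nM, a lower number beyond the scatter, while compound 3 `O=C(O)CC/C=C\CO[C@@H]1[C@@H](OCc2ccc(-c3ccccc3)cc2)CC[C@@H]1N1CCCCC1` gives 100 nM, a higher number beyond the scatter. Compound 4 `O=C(O)CC/C=C\CO[C@H]1C(OCc2ccc(-c3ccccc3CO)cc2)CC[C@@H]1N1CCCCCC1` has not yet been measured. It differs from compound 1 in one place: 2-(hydroxymethyl)phenyl in place of 3-(methanesulfonamido)phenyl on an aromatic carbon. Among the measured compounds shown here, no measured pair shows this same change, so the size of the step is open. Since compound 2 also carries a hydroxymethyl and gives 3.98 nM, a modest lowering seems plausible, though it may stay within the scatter. Compound 4 is estimated at 8 nM, with a range from 2.5 nM to 30 nM. This estimate means an expected step of a 1.6-fold lower number from compound 1 to compound 4 (0.20 log units; within the scatter).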

Compound 4, dissociation constant: 3.16 nM
Estimate against measurement, compound 4: 2.5-fold (0.40 log units) above; low and high end bracket the measured number.
By their numbers in this assay, from the lowest: compounds 4 and 2 (each within the scatter of the next); then compound 1; then compound 3.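

In this assay the aromatic ring at this position need not carry 3-(methanesulfonamido)phenyl to reach a low number: 2-(hydroxymethyl)phenyl in its place gives a 4.0-fold lower number from compound 1 to compound 4 (0.60 log units; beyond the scatter) on the shared core. The smaller group, with fewer heavy atoms, is therefore accepted here. Nothing measured here accounts for this step.

The group and its place on the ring changed together, so their separate shares cannot be told apart. On these data alone, whether an amine or a carboxylic acid on this ring would give a similar number remains open.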